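A few compounds are considered here, and "the series" means these few. Any claim that something is new, unique, unknown or untested is made for them only; others in the source may bear on it.

Working notes on the series.

Three compounds share one core and differ at the aryl group on the ring nitrogen of that core. In a functional assay on U-87MG ATCC cells for antiproliferative activity against U-87 MG (Homo sapiens), read by MTT assay, with a stated time of 72 h (a lower number here means a stronger inhibitor, a higher number a weaker inhibitor), compound 1 `CCNC(=O)c1cc(Oc2ccc(NC(=O)c3cc4cccnc4n(-c4ccc(Br)cc4)c3=O)cc2)ccn1` gives "not determined" (no result reported), and compound 3 `CCNC(=O)c1cc(Oc2ccc(NC(=O)c3cc4cccnc4n(-c4ccc(F)c(Cl)c4)c3=O)cc2)ccn1` gives "not determined" (no result reported); for both the entry holds no number. Among the compounds with values here, compound 2 `CCNC(=O)c1cc(Oc2ccc(NC(=O)c3cc4cccnc4n(-c4ccc(OC)cc4)c3=O)cc2)ccn1` is the only member with a number: in this assay compound 2 gives 7210 nM. Compound 2 therefore stands alone on the numbers shown, with no second value to set it against and no step between measured compounds to draw on.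

Compound 4 `CCCNC(=O)c1cc(Oc2ccc(NC(=O)c3cc4cccnc4n(-c4ccc(OC)cc4)c3=O)cc2)ccn1` keeps the aryl group of compound 2 and changes the amide substituent instead: methyl in place of hydrogen on a saturated chain carbon, two bonds along the chain from an amide-type nitrogen. Put in words, it is methyl in place of hydrogen on a saturated chain carbon, two bonds along the chain from an amide-type nitrogen.

Within the data shown here, no measured pair in this set tracks such a change, so the expected size of the step rests on the change itself being small. The expectation is that the step from compound 2 to compound 4 in this assay is a 1.0-fold lower number from compound 2 to compound 4 (0.01 log units; within the scatter), which is not beyond the scatter in either direction. On that basis compound 4 is estimated in this assay at 7000 nM, with a range from 3000 nM to 16000 nM.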

Compound 4, half-maximal inhibitory concentration: 8210 nM
For compound 4 the middle estimate is 1.2-fold (0.07 log units) below the measured one; the measured number falls inside the stated range.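

In this assay, within the data shown here, the change from ethylamino to propylamino gives a 1.1-fold higher number from compound 2 to compound 4 (0.06 log units; within the scatter) and so supplies the first readable step, at a place the aryl comparison of the opening compounds could not reach; compound 2 and compound 4 cannot be told apart on these numbers. For this one pair, with the methoxy-bearing aryl group held constant, methyl in place of hydrogen on a saturated chain carbon, two bonds along the chain from an amide-type nitrogen, is tolerated without a step beyond the scatter, although one pair gives no trend along the chain. No supporting data bear on this result, so it stands as an observation only.

The compounds shown leave open whether a longer chain, such as butyl or pentyl, a branched chain such as isopropyl, or a chain ending in an amine or a carboxylic acid would stay within the scatter of compound 2 at this place. Among these compounds, the effect of the aryl group on the ring nitrogen also remains unread, since compound 1 and compound 3 carry no number to set against compound 2, and no step involving either can be read.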